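The source may report more compounds than this note shows. Statements on the series, on what has been measured and on what is new or still open speak of the compounds shown alone.

- Compound 1 `COc1ccc(N2C(=O)COc3ccc(-c4ccc(O)cc4)cc32)cc1`: > 40000 nM (a limit)
- Compound 2 `COc1ccc(N2C(=O)COc3ccc(-c4cnc(Cl)c(NS(=O)(=O)c5ccc(F)cc5)c4)cc32)cc1`: 32700 nM

The measurements come from a functional assay on A-375 cells (Homo sapiens) for antiproliferative activity, read by MTT assay, with a stated time of 72 h; on this read-out lower numbers stand for stronger inhibition and higher numbers for weaker inhibition. Compound 1 has no exact value here: its result, > 40000 nM, is only a limit of the assay. This places it at the limit of > 40000 nM in this assay, at which 1 of the 2 values shown sits. Compound 2 gives a number, 32700 nM.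

Compound 3 `COc1cccc(N2C(=O)COc3ccc(-c4ccc(O)cc4)cc32)c1` has not yet been measured. It keeps the shared core of compound 1 and differs in one place: 3-methoxyphenyl in place of 4-methoxyphenyl on an amide-type nitrogen in a ring. Among the compounds with values here, no measured pair of compounds shows what this swap of 3-methoxyphenyl for 4-methoxyphenyl does. The expectation therefore rests on compound 1, whose > 40000 nM is a limit. The expected step is an at least 1.0-fold lower number from compound 1 to compound 3 (0.02 log units; that floor lies within the scatter), with no change beyond the scatter expected in this assay. Compound 3 is estimated at 38000 nM, with an expected range of 14000 nM to 70000 nM.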

Compound 3, half-maximal inhibitory concentration: 30400 nM
Compound 3: the middle estimate sits 1.3-fold (0.10 log units) above what was measured; the range from low to high includes it.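

In this assay, 3-methoxyphenyl in place of 4-methoxyphenyl on the amide-type nitrogen gives an at least 1.3-fold lower number from compound 1 to compound 3 (0.11 log units; that floor lies within the scatter). Within the data shown here, this change brings the first exact reading for this pair, since compound 3 gives 30400 nM, so the swap can be tied to a number at one end. On these data alone, the true size of the step stays unknown because the other end, compound 1, is only a limit: the limit of > 40000 nM in this assay, at which 1 of the 3 values shown sits.

The compounds shown leave open what an amine, a carboxylic acid or a longer chain such as ethoxy would do in place of the methoxy group on this phenyl ring. They also leave open whether the same swap would have any effect with the substituted pyridine of compound 2 in place of the hydroxyphenyl group.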